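Compound 3: the fluoro to methyl step

This account rests on a few compounds, and the source may have more. Where it says the series, first, only, none or still open, it means among the compounds named here.

In a physicochemical assay for lipophilicity (a higher number here means a more lipophilic compound, a lower number a more polar compound), compound 1 (`O=C1/C(=C/c2ccccc2)CCC/C1=C\c1ccccc1[N+](=O)[O-]`) gives 4.7 and compound 2 (`COc1ccc(/C=C2\CCC/C(=C\c3ccccc3[N+](=O)[O-])C2=O)cc1`) gives 4.76. Compound 3 (`O=C1/C(=C/c2ccc(F)cc2)CCC/C1=C\c1cccc([N+](=O)[O-])c1`) gives 5.07, the highest of the three numbers and beyond the scatter from both others. Compound 4 (`Cc1ccc(/C=C2\CCC/C(=C\c3cccc([N+](=O)[O-])c3)C2=O)cc1`) is not yet measured. Its structure departs from that of compound 3 by methyl in place of fluoro on an aromatic carbon, para to a large group. Among the compounds with values here, only one measured step bears on this change, and only indirectly: a number 0.06 log units higher from compound 1 to compound 2 (within the scatter), with methoxy in place of hydrogen on an aromatic carbon. Within the data shown here, no measured pair has fluoro leaving or methyl entering, so the basis for a prediction is thin. A small upward move in this assay is expected, with the estimated step being a number 0.18 log units higher from compound 3 to compound 4 (within the scatter), which would not clearly leave the scatter. The estimate for compound 4 is 5.25, with an expected range of 4.95 to 5.55.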

Compound 4, partition coefficient: 5.35
Beside the measured number, compound 4's estimate is 0.10 log units below it; low and high end bracket the measured number.
By their numbers in this assay, from the lowest: compounds 1 and 2 (each within the scatter of the next); then compounds 3 and 4 (each within the scatter of the next).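

In this assay, within the data shown here, the change from 4-fluorophenyl to 4-methylphenyl gives a number 0.28 log units higher from compound 3 to compound 4 (within the scatter), the first direct comparison of fluoro and methyl, on an aromatic carbon, para to a large group. At this read-out, the two groups cannot be told apart at this place. The earlier step, a number 0.06 log units higher from compound 1 to compound 2 (within the scatter), concerns methoxy in place of hydrogen and says nothing about either group. No measurement shown offers an explanation for the size of the step.

Still open, as far as these compounds go, is whether an amine, a carboxylic acid or a longer chain at the same place would remain within the scatter of compound 4. Also open, from the compounds shown here alone, is whether the change from fluoro to methyl would read the same on the core of compound 1, where the nitro group sits differently.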